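The source may hold more compounds than are shown below. What is called first, only, known or untested is meant among the compounds shown, and "the series" means these compounds.

The series shares one core, seen in compound 1 `Nc1cc(N)c2nc(-c3ccccc3)c(Oc3ccc(Cl)c(Cl)c3)nc2c1` and in compound 2 `COc1cc(CNc2nc3cc(N)cc(N)c3nc2-c2ccccc2)cc(OC)c1OC`. In a functional assay on K562 cells (Homo sapiens) for inhibition, read by sulforhodamine B assay, with a stated time of 48 h (on this read-out higher numbers stand for weaker inhibition of growth and lower numbers for stronger inhibition of growth), compound 1 gives 3550 nM, the highest of the two numbers recorded so far. Its nearest neighbour is compound 2, which in this assay gives 1780 nM; the gap between these two values lies within the scatter of the method, so the two compounds cannot be told apart on this read-out. Among the compounds with values here, no pair of measured compounds differs in a single place, so no measured step is available to guide expectations.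

Compound 3 `Nc1cc(N)c2nc(-c3ccccc3)c(Sc3ccc(Cl)c(Cl)c3)nc2c1` has not yet been measured. It differs from compound 1 in one place: (3,4-dichlorophenyl)sulfanyl in place of 3,4-dichlorophenoxy on an aromatic carbon. Within the data shown here, with no measured step to draw on, and with the two recorded values sitting within the scatter of one another, the step from compound 1 to compound 3 is expected to be small, with no direction that reaches beyond the scatter: a 1.2-fold lower number from compound 1 to compound 3 (0.07 log units; within the scatter). Compound 3 is accordingly estimated to give 3000 nM in this assay, with a range from 1200 nM to 8000 nM.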

Compound 3, concentration for 50% growth inhibition: 15800 nM
Beside the measured number, compound 3's estimate is 5.3-fold (0.72 log units) below it; measured number above the stated range.
By their numbers in this assay, from the lowest: compounds 2 and 1 (each within the scatter of the next); then compound 3.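

Within the data shown here, the step from 3,4-dichlorophenoxy to (3,4-dichlorophenyl)sulfanyl gives the first measured change at this position on an aromatic carbon: in this assay, there is a 4.5-fold higher number from compound 1 to compound 3 (0.65 log units; beyond the scatter), so growth inhibition weakens beyond the scatter. The two groups match in heavy-atom count, in their six-membered aromatic ring of carbon only, in hydrogen-bond donors and acceptors, and in net charge, and the count differs only in oxygen against sulfur. The earlier compounds offered no single-place comparison, whereas this pair shows that the read-out can separate two groups this closely matched, although the finding rests on this one pair and nothing here gives a reason for the change.

Going by these compounds, it remains open whether a sulfonyl or a methylene link at this position would give a number nearer to that of compound 1 or to that of compound 3. On these data alone, it is also open whether the same exchange would give a step of similar size and direction with a pyridyl group in place of the phenyl group on the shared core.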